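The source may hold more compounds than are shown below. What is called first, only, known or untested is meant among the compounds shown, and "the series" means these compounds.

In an assay for inhibition of HSP60/HSP10 (Homo sapiens), with a stated time of 60 min (on this read-out higher numbers stand for weaker inhibition and lower numbers for stronger inhibition), three compounds have been measured so far. Compound 1 `COc1ccccc1C(=O)Nc1cccc(Cl)c1` gives > 100000 nM, which is a limit of this assay rather than a number. Compound 3 `COc1c(Br)cccc1C(=O)Nc1cccc(Cl)c1` gives > 100000 nM in this assay, again a limit. Compound 2 `O=C(Nc1ccc(Sc2nc3ccccc3s2)c(Cl)c1)c1cc(Br)ccc1O` gives > 100000 nM in this assay, also a limit. The change from compound 3 to compound 1, (hydrogen in place of bromo on an aromatic carbon), gives a step that the two limits leave unreadable from compound 3 to compound 1, since both values sit at the limit of > 100000 nM in this assay, at which 3 of the 3 values shown sit. The difference between the core of compound 2 and the core of compound 3 is not broken down here.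

Compound 4 `O=C(Nc1ccc(Sc2nc3ccccc3s2)c(Cl)c1)c1ccccc1O` is still to be measured in this assay. It differs from compound 2 by hydrogen in place of bromo on an aromatic carbon. This is the same kind of change as from compound 3 to compound 1, but the surroundings differ: there the carbon is ortho to a methoxy group, here it is para to a hydroxy group. In this assay the step from compound 2 to compound 4 is expected to be a number no higher from compound 2 to compound 4 (the limit leaves the size open), resting on (the limit of > 100000 nM in this assay, at which 3 of the 3 values shown sit). Compound 4 is therefore estimated at 100000 nM, most likely reported once more as a limit.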

Compound 4, half-maximal inhibitory concentration: > 100000 nM
Compound 4: a limit, no number; the forecaster's own chance of this, stated with the estimate: 80%; the middle value lies on the limit itself.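

Compound 2 and compound 4 both give only a limit in this assay, so no step can be read for hydrogen in place of bromo between them: the limit of > 100000 nM in this assay, at which 4 of the 4 values shown sit.

The compounds shown leave open whether bromo makes any difference to inhibition, and which structures would give an actual number rather than a limit in this assay.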